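From methyl to benzyl on a shared core

The compounds below may be only part of what the source reports. "The series", "measured", "known", "first", "only" and "open" are said of these compounds alone.

compound 1 `COC(=O)NC1=NC(c2ccccc2)CN1C` gives 107 mg/kg
compound 2 `CCOC(=O)NC1=NC(c2ccccc2)CN1C` gives 78 mg/kg
compound 3 `COC(=O)NC1=NC(c2ccc(Cl)cc2)CN1C` gives 66 mg/kg

In a functional assay on the whole organism for antagonist activity, with Mus musculus as the target, in the maximal electroshock model (a lower number here means that less compound is needed, a higher number that more compound is needed for the effect), compound 1 gives 107 mg/kg and both steps measured from it lie within the usual scatter, so the three values do not separate.

The unmeasured compound 4 `COC(=O)NC1=NC(c2ccccc2)CN1Cc1ccccc1` differs from compound 1 in one place, with phenyl in place of hydrogen on a saturated chain carbon bound to an amine nitrogen in a ring, so that methyl turns to benzyl (phenyl in place of hydrogen on a saturated chain carbon bound to an amine nitrogen in a ring).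

Within the data shown here, two measured steps bear on this only loosely. There is a 1.4-fold lower number from compound 1 to compound 2 (0.14 log units; within the scatter) for methyl in place of hydrogen on a saturated chain carbon bound to an oxygen next to a carbonyl group, and there is a 1.6-fold lower number from compound 1 to compound 3 (0.21 log units; within the scatter) for chloro in place of hydrogen on an aromatic carbon. Neither touches the place that changes here, and no other group at that place has been measured. They offer no direction, so no step beyond the scatter is expected.

The expected outcome is a 1.1-fold lower number from compound 1 to compound 4 (0.03 log units; within the scatter) and the data support nothing more definite. For compound 4 the estimated value is 100 mg/kg with an expected range from 40 mg/kg to 250 mg/kg and that range is deliberately wide.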

Compound 4, dose for half-maximal effect: 100 mg/kg
Compound 4: the middle estimate sits on the measured number at the digits printed, and the stated range covers the measured number.
By their numbers in this assay, from the lowest: compounds 3, 2, 4 and 1 (each within the scatter of the next).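

Compound 4 is the first of these compounds changed at the saturated chain carbon bound to an amine nitrogen in a ring, and in this assay phenyl in place of hydrogen there gives a 1.1-fold lower number from compound 1 to compound 4 (0.03 log units; within the scatter) as its step. The earlier compounds shown here said nothing about this place, and this result shows that it can carry an added aromatic ring of six carbon atoms, turning methyl into benzyl, with no change that can be told apart from the usual spread of repeated measurements. Nothing in the available data offers a reason for this outcome, and no measurement of any property of these compounds bears on it.

Among the compounds shown, methyl and benzyl are the only groups at this place, so it remains open whether a longer chain such as phenylethyl, or a benzyl ring carrying an amine or a carboxylic acid, would move the dose beyond that spread. Also open, on these data alone, is what benzyl at this place would give together with the chloro group of compound 3.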